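Swapping the bicyclic amine on a quinoline-type core

This account rests on a few compounds, and the source may have more. Where it says the series, first, only, none or still open, it means among the compounds named here.

Measured so far:
compound 1 `Nc1ccc2cc(NC(=O)CCc3ccc(C(F)(F)F)cc3)ccc2n1`: 720 nM
compound 2 `O=C(CCc1ccc(C(F)(F)F)cc1)Nc1ccc2nc(N3CC4CC3CO4)ccc2c1`: 70 nM

In a functional assay on HEK293 cells for activation of melanin-concentrating hormone receptor 1 (Rattus norvegicus), read by inositol phosphate accumulation (on this read-out higher numbers stand for an effect only at larger amounts of compound and lower numbers for an effect already at smaller amounts), compound 2 gives 70 nM, the lowest of the two numbers, and compound 1 gives 720 nM. Within the data shown here, the one measured step, a 10-fold lower number from compound 1 to compound 2 (1.01 log units; beyond the scatter), came from putting a bicyclic amine in place of a primary amine on the shared core.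

Compound 3 `O=C(CCc1ccc(C(F)(F)F)cc1)Nc1ccc2nc(N3CCC4(CCNC4)C3)ccc2c1` is not yet measured. It differs from compound 2 by a group of 9 heavy atoms (7 carbon, 2 nitrogen; 2 five-membered non-aromatic rings with 1 hetero atom each) in place of a group of 7 heavy atoms (5 carbon, 1 nitrogen, 1 oxygen; 2 five-membered non-aromatic rings with 1 hetero atom each), on an aromatic carbon. Among the measured compounds shown here, this keeps a bicyclic amine of similar shape at the same place, so the step that made compound 2 better than compound 1 is the only guide, and it speaks for a bicyclic amine being well tolerated there. Nothing measured shows how this particular exchange acts. Compound 3 is therefore expected to stay near compound 2, with a 1.6-fold lower number from compound 2 to compound 3 (0.19 log units; within the scatter) at most a modest change; the estimate for compound 3 is 45 nM, between 9 nM and 220 nM.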

Compound 3, half-maximal effective concentration: 140 nM
Compound 3: the middle estimate sits 3.1-fold (0.49 log units) below what was measured, within the range that was stated.
By their numbers in this assay, from the lowest: compounds 2 and 3 (each within the scatter of the next); then compound 1.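

In this assay this position accepts a second, larger bicyclic amine, one with an added hydrogen-bond donor and a nitrogen where compound 2 has its oxygen, and the exchange gives a 2.0-fold higher number from compound 2 to compound 3 (0.30 log units; within the scatter). Compound 3 therefore cannot be told apart from compound 2, while the gain over the primary amine appears a second time as a 5.1-fold lower number from compound 1 to compound 3 (0.71 log units; beyond the scatter), so both bicyclic amines stand apart from compound 1 and neither goes against that pattern. No measurement at hand explains these numbers.

From the compounds shown here alone, whether a single-ring amine such as piperidine or morpholine would do as well as these two bicyclic amines stays open. So does what a methyl group on the free ring nitrogen of compound 3 would do in this position.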